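This account rests on a few compounds, and the source may have more. Where it says the series, first, only, none or still open, it means among the compounds named here.

Three compounds have been measured in a functional assay on BE(2)-C cells (Homo sapiens) for inhibition, read by MTT assay, with a stated time of 72 h; a higher number here means a weaker inhibitor of growth, a lower number a stronger inhibitor of growth:

compound 1 `O=S(=O)(NCCCNCc1cccc2ccccc12)c1cc(C(F)(F)F)cc(C(F)(F)F)c1`, 2700 nM
compound 2 `O=S(=O)(NCCCCNCc1ccc(Br)cc1)c1cc(C(F)(F)F)cc(C(F)(F)F)c1`, 2200 nM
compound 3 `COc1cccc(CNCCCNS(=O)(=O)c2cc(C(F)(F)F)cc(C(F)(F)F)c2)c1`, 4500 nM

Compound 1 gives the second highest of these three numbers. Its nearest neighbour is compound 2, whose value lies within the scatter of it, and compound 3 lies furthest from it, yet still within the scatter. Compound 4 `O=S(=O)(NCCCNCc1ccccc1)c1cc(C(F)(F)F)cc(C(F)(F)F)c1` has not been measured. It differs from compound 1 in one place: phenyl in place of naphthalen-1-yl on a saturated chain carbon bound to an amine nitrogen.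

Among the compounds with values here, one measured step bears directly on this change. The step of a 1.7-fold higher number from compound 1 to compound 3 (0.22 log units; within the scatter) also replaces naphthalen-1-yl on the saturated chain carbon bound to an amine nitrogen, there with 3-methoxyphenyl, and it moved the number only a little upward. The step of a 2.0-fold higher number from compound 2 to compound 3 (0.31 log units; beyond the scatter) is less closely related, as it alters the chain as well, but it points the same way. On this basis compound 4 is expected to give a number near that of compound 1 or somewhat higher, with the estimated step of a 1.5-fold higher number from compound 1 to compound 4 (0.17 log units; within the scatter) likely within the scatter or only modestly beyond it. Compound 4 is therefore estimated at 4000 nM in this assay, with a range from 1800 nM to 9000 nM.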

Compound 4, concentration for 50% growth inhibition: 12000 nM
Compound 4: middle estimate off by 3.0-fold (0.48 log units), on the low side, and the stated range ends below it.
By their numbers in this assay, from the lowest: compounds 2, 1 and 3 (each within the scatter of the next, the first and the last beyond it); then compound 4.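

In this assay, the change from naphthalen-1-yl to phenyl gives a 4.4-fold higher number from compound 1 to compound 4 (0.65 log units; beyond the scatter), which lies beyond the scatter, whereas 3-methoxyphenyl at the same place had stayed within it, so this position does discriminate between aromatic groups. Removing only the methoxy gives a 2.7-fold higher number from compound 3 to compound 4 (0.43 log units; beyond the scatter), which shows that the unsubstituted phenyl stands apart from both the methoxy-bearing ring and the naphthalen-1-yl group, and that a single ring with a methoxy on it is not equivalent to a bare one. The last step, a 5.5-fold higher number from compound 2 to compound 4 (0.74 log units; beyond the scatter), is the largest of the three, but it changes the chain and removes the bromine together, so its size cannot be divided between those two changes.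

Nothing available explains why the bare phenyl gives the highest number of the four. From the compounds shown here alone, it remains open whether a chlorine or a methyl on the phenyl would bring the number back towards that of compound 3, whether a pyridine ring would behave like phenyl, and how much of the last step belongs to the chain and how much to the bromine.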